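The compounds below may be only part of what the source reports. "The series", "measured", "known", "first", "only" and "open" are said of these compounds alone.

Compound 2 `O=C(/C=C\c1ccc(F)cc1)N1N=C(c2ccncc2)OC1c1c[nH]c2ccccc12` shares its core with compound 1 `O=C(/C=C\c1ccccc1[N+](=O)[O-])N1N=C(c2ccncc2)OC1c1c[nH]c2ccccc12`; the two differ only at the aryl group on the ethenyl chain. In an ADME assay on HeLa cells (Homo sapiens) for cytotoxicity, read by MTT assay, with a stated time of 72 h (on this read-out higher numbers stand for weaker inhibition of growth and lower numbers for stronger inhibition of growth), compound 1 gives a limit of the assay, > 30 ug/mL. In this assay compound 2 likewise gives only a limit, > 30 ug/mL. The step from compound 1 to compound 2 therefore cannot be read: a step that the two limits leave unreadable from compound 1 to compound 2. Both values sit at the same edge of the assay, (the limit of > 30 ug/mL in this assay, at which 2 of the 2 values shown sit), so compound 2 stands at the limit with no number beneath it.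

Compound 3 `O=C(/C=C\c1ccccc1Cl)N1N=C(c2ccncc2)OC1c1c[nH]c2ccccc12` is the next member, with the change (2-chlorophenyl in place of 4-fluorophenyl on a double-bonded chain carbon bound to a double-bonded chain carbon). Among the compounds with values here, the only measured step on this chain carbon, from compound 1 to compound 2, is unreadable, and no other step bears on the change to a 2-chlorophenyl group. The step from compound 2 to compound 3 is accordingly expected to be small or not visible, a step that the limit leaves unreadable from compound 2 to compound 3, with a good chance that only a limit is reported again. Compound 3 is estimated at 40 ug/mL in this assay, within the range 15 ug/mL to 100 ug/mL.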

Compound 3, concentration for 50% growth inhibition: > 30 ug/mL
Compound 3: only a limit was reported; the forecaster's own chance of this, stated with the estimate: 70%; the middle value is on the limit's open side.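

In this assay compound 3 also gives only a limit, > 30 ug/mL. Within the data shown here, no step among compound 1, compound 2 and compound 3 can be read: the limit of > 30 ug/mL in this assay, at which 3 of the 3 values shown sit. From the compounds shown here alone, whether these aryl groups on the ethenyl chain differ in growth inhibition remains open.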